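The compounds below may be only part of what the source reports. "The series", "measured", "known", "first", "only" and "open" are said of these compounds alone.

Working notes on the series. The shared core carries a cyclopropyl-bearing nitrogen linked through an amide to an amino-acid benzyl ester or acid, and the compounds are compared in a functional assay on the whole organism (Tail, strain ICR) with Mus musculus as the target, in the tail flick test, with a stated time of 90 min, at a dose of 25 umol/kg by the oral route; a lower number here means a weaker effect, a higher number a stronger effect of the compound at the dose given. Compound 1 `O=C(CN(c1nc(Cl)nc2[nH]cnc12)C1CC1)N[C@@H](CO)C(=O)OCc1ccccc1` gives 34.5% in this assay. Compound 2 `NC(=O)CC[C@H](NC(=O)CN(c1ncnc2c1ncn2C1CCCCO1)C1CC1)C(=O)OCc1ccccc1` gives 37.8%, and compound 3 `O=C(O)[C@@H]1CCCN1C(=O)CN(c1nc(Cl)nc2[nH]cnc12)C1CC1` gives 26%. All three numbers lie within the usual scatter of one another, so no order can be read among them: the nearest number to compound 1 is that of compound 2, the furthest that of compound 3, and both gaps are within the scatter.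

Compound 4 `O=C(CN(c1nc(Cl)nc2[nH]cnc12)C1CC1)NCC(=O)OCc1ccccc1` is not yet measured in this assay. Relative to compound 1 it differs as follows: hydrogen in place of hydroxymethyl on a saturated chain carbon bound to an amide-type nitrogen and a carbonyl carbon. Going by the values given here, no measured pair in the set differs in just one place, so there is no reference for a single change of this kind. Given that the three measured compounds, which differ from one another in several places, still fall within the scatter of each other, no step beyond the scatter in either direction is expected here. For compound 4 the expected step is a number 2.5 percentage points lower from compound 1 to compound 4 (within the scatter). Compound 4 is estimated at 32%, within a range of 20% to 45%.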

Compound 4, a percentage reported as activity, at one dose (the size of the read-out at that dose, not a potency): 27.2%
Beside the measured number, compound 4's estimate is 4.8 percentage points above it, and the stated range covers the measured number.
By their numbers in this assay, from the lowest: compounds 3, 4, 1 and 2 (each within the scatter of the next, the first and the last beyond it).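

This pair gives the series its first change in a single place: in this assay, hydrogen in place of hydroxymethyl on a saturated chain carbon bound to an amide-type nitrogen and a carbonyl carbon gives a number 7.3 percentage points lower from compound 1 to compound 4 (within the scatter) as the step. The read-out at this one dose therefore does not separate the two compounds, and the loss of the hydroxymethyl, with its 2 heavy atoms, leaves no change that can be told from the usual scatter. No independent measurement bears on this result, so the step stands without an explanation.

The compounds shown leave open how a methyl or an aminomethyl group would read on this same saturated chain carbon, as only hydroxymethyl and hydrogen can be compared there. They also leave open whether the same exchange would stay within the scatter at another dose or at another time after dosing, as this pair gives a single read-out for each compound.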